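A few compounds are considered here, and "the series" means these few. Any claim that something is new, unique, unknown or untested is made for them only; others in the source may bear on it.

Measured so far in a functional assay for antagonist activity at Alpha-1A adrenergic receptor (Oryctolagus cuniculus); a lower number here means tighter binding, a higher number weaker binding:
compound 1 `Cc1cnccc1N1CCN(CCCNc2ncccc2C(=O)N(C)C)CC1` gives 200 nM
compound 2 `CSc1ccccc1N1CCN(CCCNc2ncccc2C(=O)N(C)C)CC1` gives 0.631 nM
compound 3 `COc1cc(O)ccc1N1CCN(CCCNc2ncccc2C(=O)N(C)C)CC1` gives 12.6 nM

Compound 3 holds the second highest of the three numbers in this assay. Among the three it stands nearest to compound 1 and furthest from compound 2; the steps in question are a 16-fold lower number from compound 1 to compound 3 (1.20 log units; beyond the scatter) and a 20-fold higher number from compound 2 to compound 3 (1.30 log units; beyond the scatter). The remaining step, a 320-fold lower number from compound 1 to compound 2 (2.50 log units; beyond the scatter), is the largest of the set.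

Compound 4 `COc1ccc(N2CCN(CCCNc3ncccc3C(=O)N(C)C)CC2)c(OC)c1` differs from compound 3 by methyl in place of hydrogen on an oxygen on an aromatic ring. For the measured compounds named here, every measured step exchanges the whole aryl group on the ring amine nitrogen; none alters only a single substituent on that group, so no measured step bears directly on this change. The three steps do show that the aryl group governs much of the spread in this assay, so a shift cannot be excluded, but nothing measured fixes its direction. The step from compound 3 to compound 4 is therefore expected to be small, near or within the scatter: a 1.6-fold lower number from compound 3 to compound 4 (0.20 log units; within the scatter). Compound 4 is estimated at 8 nM in this assay, with a range from 2 nM to 30 nM.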

Compound 4, dissociation constant: 31.6 nM
The estimate for compound 4 lay 4.0-fold (0.60 log units) below the measured number, outside the stated range (above it).
By their numbers in this assay, from the lowest: compound 2; then compound 3; then compound 4; then compound 1.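

In this assay, methyl in place of hydrogen on the oxygen, turning 4-hydroxy-2-methoxyphenyl into 2,4-dimethoxyphenyl, gives a 2.5-fold higher number from compound 3 to compound 4 (0.40 log units; beyond the scatter); this is the only step shown that alters one substituent rather than the whole aryl group, and it shows that this oxygen position is not silent. The change is modest beside a 50-fold higher number from compound 2 to compound 4 (1.70 log units; beyond the scatter), and a 6.3-fold lower number from compound 1 to compound 4 (0.80 log units; beyond the scatter) shows that 2,4-dimethoxyphenyl still keeps a lower number than 3-methylpyridin-4-yl. Nothing available accounts for the direction of the step.

On these data alone, whether the step follows from the hydrogen lost or the methyl gained remains open, and an ethoxy group, an amine or a fluorine at this place would bear on that. Also open, as far as these compounds go, is whether the same change would carry over to the 2-(methylsulfanyl)phenyl group.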